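A few compounds are considered here, and "the series" means these few. Any claim that something is new, unique, unknown or untested is made for them only; others in the source may bear on it.

In a functional assay on MCF7 cells (Homo sapiens) for antiproliferative activity, with a stated time of 48 h (on this read-out higher numbers stand for weaker inhibition of growth and lower numbers for stronger inhibition of growth), compound 1 `Cc1cc(O)c(C2=NN(c3ccc(S(N)(=O)=O)cc3)C(c3ccccc3O)C2)cc1Cl` gives 9770 nM, while compound 2 `Cc1cc(O)c(C2=NN(c3ccc(S(N)(=O)=O)cc3)C(c3ccccc3Cl)C2)cc1Cl` gives 3330 nM. Within the data shown here, the only measured step, a 2.9-fold lower number from compound 1 to compound 2 (0.47 log units; beyond the scatter), leaves compound 2 standing lowest of the two numbers. Compound 3 `Cc1cc(O)c(C2=NN(c3ccc(S(N)(=O)=O)cc3)C(/C=C/c3ccccc3)C2)cc1Cl` differs from compound 2 by 2-phenylethenyl in place of 2-chlorophenyl on a saturated ring carbon. That measured step touched the same ring carbon, yet it only exchanged one group on the aryl ring, so it is a weak guide for replacing the whole ring; no shift beyond the scatter is expected. Compound 3 is therefore expected to give about 4000 nM, within a range from 1300 nM to 12000 nM. The expected step is a 1.2-fold higher number from compound 2 to compound 3 (0.08 log units; within the scatter).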

Compound 3, concentration for total growth inhibition: 16100 nM
Compound 3: middle estimate off by 4.0-fold (0.60 log units), on the low side; the whole stated range lies below it.
By their numbers in this assay, from the lowest: compound 2; then compounds 1 and 3 (each within the scatter of the next).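

The saturated ring carbon tolerates more than small changes on its aryl ring: in this assay, 2-phenylethenyl in place of 2-chlorophenyl gives a 4.8-fold higher number from compound 2 to compound 3 (0.68 log units; beyond the scatter) and so gives up the advantage that the chloro compound held. Set against 2-hydroxyphenyl, the same group gives a 1.6-fold higher number from compound 1 to compound 3 (0.22 log units; within the scatter) and leaves those two compounds indistinguishable on this read-out. Nothing available explains these results. The compounds shown leave open whether the double bond itself matters, which a 2-phenylethyl group at this carbon would test. Going by these compounds, how a 2-aminophenyl group would compare also remains open.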